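Replacing 2-fluorophenyl with naphthalen-2-yl in a cytotoxicity series

The source may report more compounds than this note shows. Statements on the series, on what has been measured and on what is new or still open speak of the compounds shown alone.

Three compounds have values in an ADME assay on L6 cells (Rattus norvegicus) for cytotoxicity, read by resazurin assay (on this read-out lower numbers stand for stronger inhibition and higher numbers for weaker inhibition), so far
Compound 1 (`N=C(N)c1ccc2[nH]c(-c3ccc4nc(-c5ccccc5F)[nH]c4c3)nc2c1`) gives 26.8 ug/mL
Compound 2 (`CC(C)(C)c1cccc(-c2nc3ccc(-c4nc5cc(C(=N)N)ccc5[nH]4)cc3[nH]2)c1O`) gives 13.4 ug/mL
Compound 3 (`N=C(N)c1ccc2[nH]c(-c3ccc4nc(-c5cc(C(F)(F)F)ccc5Cl)[nH]c4c3)nc2c1`) gives 31.8 ug/mL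

Compound 1 stands in the middle of these three numbers, and it lies within the scatter of both compound 2 and compound 3. The next compound, compound 4 (`N=C(N)c1ccc2[nH]c(-c3ccc4nc(-c5ccc6ccccc6c5)[nH]c4c3)nc2c1`), keeps the core of compound 1 but has naphthalen-2-yl in place of 2-fluorophenyl on an aromatic carbon. Among the measured compounds shown here, no two measured compounds differ in one place only, so no direct precedent exists for this change. Compound 2 and compound 3 carry other groups at that place, yet neither value moves beyond the scatter from that of compound 1. In this assay no step beyond the scatter is therefore expected, with a slight lean toward a lower number. The expected step of a 1.5-fold lower number from compound 1 to compound 4 (0.17 log units; within the scatter) is an estimate with wide uncertainty. Compound 4 is expected at 18 ug/mL within an estimated range of 7 ug/mL to 42 ug/mL once measured.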

Compound 4, half-maximal inhibitory concentration: 34.7 ug/mL
Beside the measured number, compound 4's estimate is 1.9-fold (0.29 log units) below it, within the range that was stated.
By their numbers in this assay, from the lowest: compounds 2, 1, 3 and 4 (each within the scatter of the next, the first and the last beyond it).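

In this assay, the first step read at this place, a 1.3-fold higher number from compound 1 to compound 4 (0.11 log units; within the scatter), stays within the scatter. The place on an aromatic carbon between two ring nitrogen atoms therefore accepts naphthalen-2-yl, with 2 six-membered aromatic rings of carbon only and 10 heavy atoms, in place of 2-fluorophenyl, with one such ring and 7 heavy atoms, without a step beyond the scatter. Nothing measured alongside these values accounts for this result or connects it to a property of either group.

Every group shown at this place is built on an aromatic carbon ring, so it remains open whether a pyridine ring, a morpholine, a carboxylic acid or an open alkyl chain would also stay within the scatter. Also open, on these data alone, is whether a step beyond the scatter can arise at this place on the core of compound 1 at all.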